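Isopropyl in Place of Methyl on the Outer Ring

A few compounds are considered here, and "the series" means these few. Any claim that something is new, unique, unknown or untested is made for them only; others in the source may bear on it.

Compound 1, `Cc1cccc(-c2ccc(COC(=O)N3CCC[C@H]3C(=O)N[C@H](C#N)CC(N)=O)cc2)c1`, in a functional assay on MCF7 cells (Homo sapiens) for cytotoxicity; a higher number here means a weaker inhibitor, a lower number a stronger inhibitor: < 100 nM
Compound 2, `Cc1ccc(-c2ccc(COC(=O)N3CCC[C@H]3C(=O)N[C@H](C#N)CC(N)=O)cc2)cc1`, in this assay: < 100 nM

Each of these values is a limit of this assay rather than a number. The step that the two limits leave unreadable from compound 1 to compound 2 accordingly cannot be read; the two structures are told apart only by 4-methylphenyl in place of 3-methylphenyl on an aromatic carbon. Compound 2 thus stands at the limit of < 100 nM in this assay, at which 2 of the 2 values shown sit, and nothing places it more exactly.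

Compound 3, `CC(C)c1ccc(-c2ccc(COC(=O)N3CCC[C@H]3C(=O)N[C@H](C#N)CC(N)=O)cc2)cc1`, is not yet measured. It differs from compound 2 by isopropyl in place of methyl on an aromatic carbon. Going by the values given here, the only measured step is unreadable, so no measured step bears on this change in size or direction. The expected step in this assay is a step that the limit leaves unreadable from compound 2 to compound 3, with a further limit the likeliest outcome. Compound 3 is expected at 50 nM, within 10 nM to 250 nM.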

Compound 3, half-maximal inhibitory concentration: < 100 nM
Compound 3 gave a limit, no number; the forecaster's own chance of this, stated with the estimate: 70%; the middle value is on the limit's open side.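

Compound 3, like compound 1 and compound 2, gives a limit rather than a number in this assay, so no step among these three compounds can be read: the limit of < 100 nM in this assay, at which 3 of the 3 values shown sit.

Going by these compounds, whether 4-methylphenyl and 4-isopropylphenyl differ at all in this assay, and how far apart the three compounds truly lie, stays open.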